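The compounds below may be only part of what the source reports. "The series", "measured", "known", "first", "only" and "open" are said of these compounds alone.

Measured so far in a functional assay on HepG2 cells (Homo sapiens) for antiproliferative activity, read by MTT assay; a higher number here means a weaker inhibitor, a lower number a stronger inhibitor:
Compound 1 `COc1cc2ncnc(NCc3cccc(NC(=O)Nc4ccccc4C)c3)c2cc1OC` gives only a limit of the assay, > 50000 nM.
Compound 2 `COc1cc2ncnc(NCc3cccc(NC(=O)Nc4cccc(C)c4)c3)c2cc1OC` gives 21500 nM.
Compound 3 `COc1cc2ncnc(NCc3cccc(NC(=O)Nc4ccc(C(C)(C)C)cc4)c3)c2cc1OC` gives 6850 nM.

Compound 3 has the lowest number of the two numbers in this assay; the nearest is compound 2, separated by a 3.1-fold lower number from compound 2 to compound 3 (0.50 log units; beyond the scatter). Compound 1 sits at a limit (the limit of > 50000 nM in this assay, at which 1 of the 3 values shown sits).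

Compound 4 `COc1cc2ncnc(NCc3cccc(NC(=O)Nc4ccccc4Cl)c3)c2cc1OC` carries the change (2-chlorophenyl in place of 4-(tert-butyl)phenyl on an amide-type nitrogen). For the measured compounds named here, two measured steps bear on it: an at least 7.2-fold lower number from compound 1 to compound 3 (0.86 log units; beyond the scatter), where compound 1 carries 2-methylphenyl, and a 3.1-fold lower number from compound 2 to compound 3 (0.50 log units; beyond the scatter). Both show higher numbers once 4-(tert-butyl)phenyl is absent, and compound 1 with its 2-methylphenyl reached only a limit. For compound 4 a step of a 5.8-fold higher number from compound 3 to compound 4 (0.77 log units; beyond the scatter) towards a weaker inhibitor is therefore expected, with a real chance of a limit. The estimate for compound 4 is 40000 nM, range 12000 nM to 120000 nM.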

Compound 4, half-maximal inhibitory concentration: 25500 nM
Compound 4: middle estimate off by 1.6-fold (0.20 log units), on the high side; measured number inside the range.
By their numbers in this assay, from the lowest: compound 3; then compounds 2 and 4 (each within the scatter of the next). At a limit, above all of these: compound 1.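

In this assay, a 3.7-fold higher number from compound 3 to compound 4 (0.57 log units; beyond the scatter) shows that 2-chlorophenyl on an amide-type nitrogen also stays behind 4-(tert-butyl)phenyl. Against 3-methylphenyl, 2-chlorophenyl shows no separation: a 1.2-fold higher number from compound 2 to compound 4 (0.07 log units; within the scatter). Chloro in place of methyl on an aromatic carbon gives an at least 1.9-fold lower number from compound 1 to compound 4 (0.29 log units; that floor lies within the scatter), so no real difference is established, and compound 1 gives only a limit of the assay: the limit of > 50000 nM in this assay, at which 1 of the 4 values shown sits.

The compounds shown do not separate the effect of the tert-butyl group from that of its place on the phenyl ring. From the compounds shown here alone, how an amine or a carboxylic acid on that ring would compare remains open.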